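A few compounds are considered here, and "the series" means these few. Any claim that something is new, unique, unknown or untested is made for them only; others in the source may bear on it.

Working notes on the series. Compound 3 `CCOC(CCSc1nc(-c2ccccc2)c(-c2ccccc2)[nH]1)OCC` gives 69 nM in an assay on microsomes from liver for inhibition of sterol O-acyltransferase 1 (Rattus norvegicus) (on this read-out lower numbers stand for stronger inhibition and higher numbers for weaker inhibition), the lowest of the three numbers; compound 1 `CO[C@H]1C[C@H](O)C[C@@H](CSc2nc(-c3ccccc3)c(-c3ccccc3)[nH]2)O1` gives 90 nM, a gap within the scatter, while compound 2 `O=C1CCCC(CSc2nc(-c3ccccc3)c(-c3ccccc3)[nH]2)O1` gives 740 nM, with an 11-fold lower number from compound 2 to compound 3 (1.03 log units; beyond the scatter). Compound 4 `c1ccc(-c2nc(SCC3CCCCC3)[nH]c2-c2ccccc2)cc1` carries cyclohexyl in place of 2,2-diethoxyethyl on a saturated chain carbon bound to a sulfur. Among the compounds with values here, no measured step removes both oxygen acceptors, so the comparison is indirect: a 1.3-fold lower number from compound 1 to compound 3 (0.12 log units; within the scatter) shows that exchanging one acceptor-bearing group for another costs little, whereas an 8.2-fold higher number from compound 1 to compound 2 (0.91 log units; beyond the scatter) shows that a change at this position can be felt. A modest weakening is expected for compound 4, a 3.2-fold higher number from compound 3 to compound 4 (0.50 log units; beyond the scatter), with wide uncertainty. The estimate for compound 4 in this assay is 220 nM, within 50 nM to 1000 nM.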

Compound 4, half-maximal inhibitory concentration: 100 nM
The estimate for compound 4 lay 2.2-fold (0.34 log units) above the measured number, and the stated range covers the measured number.
By their numbers in this assay, from the lowest: compounds 3, 1 and 4 (each within the scatter of the next); then compound 2.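

In this assay, a 1.4-fold higher number from compound 3 to compound 4 (0.16 log units; within the scatter) shows that cyclohexyl in place of 2,2-diethoxyethyl, on a saturated chain carbon bound to a sulfur, removes all hydrogen-bond acceptors from the group with no change beyond the scatter. With a 1.1-fold higher number from compound 1 to compound 4 (0.05 log units; within the scatter) as well, oxygen in this group is not needed for a number of this size, while a 7.4-fold lower number from compound 2 to compound 4 (0.87 log units; beyond the scatter) shows that an all-carbon ring does not share the weak number of the oxygen-bearing ring with the carbonyl. No evidence bears on why these groups perform alike. From the compounds shown here alone, whether an amine, a carboxylic acid or a longer chain at this place would hold the number remains open.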